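The compounds below may be only part of what the source reports. "The series", "measured", "known", "first", "only" and "open" are said of these compounds alone.

Going by the values given here, compound 2 `CCOC(=O)C1=C(C)NC(C)=C(C(=O)OCC)C1c1ccc(OCC(=O)NNC(=O)c2ccsc2Cl)cc1` gives 42.3% in a functional assay on the whole organism (strain Wistar) for inhibition, with Rattus norvegicus as the target, read by paw edema, with stated times of 30 min and 1 h, at a dose of 20 mg/kg (on this read-out higher numbers stand for more inhibition at the one dose given (going by the name of the read-out) and lower numbers for less inhibition), the lowest of the two numbers measured so far. The other, compound 1 `CCOC(=O)C1=C(C)NC(C)=C(C(=O)OCC)C1c1ccc(OCC(=O)NNC(=O)c2cccs2)cc1`, gives 55.1%, and the step of a number 12.8 percentage points lower from compound 1 to compound 2 (beyond the scatter) came with a 2-chlorothiophen-3-yl in place of thiophen-2-yl on a carbonyl carbon. Among the compounds with values here, compound 3 `CCOC(=O)C1=C(C)NC(C)=C(C(=O)OCC)C1c1ccc(OCc2nnc(S)o2)cc1` alters compound 2 in a different place: a group of 6 heavy atoms (2 carbon, 2 nitrogen, 1 oxygen, 1 sulfur; one five-membered aromatic ring with 3 hetero atoms) in place of a group of 12 heavy atoms (6 carbon, 2 nitrogen, 2 oxygen, 1 sulfur, 1 chlorine; one five-membered aromatic ring with 1 hetero atom), on a saturated chain carbon bound to an oxygen on an aromatic ring No measured step matches this exchange, so the two values alone set the scale, and the step of a number 2.7 percentage points higher from compound 2 to compound 3 (within the scatter) is expected to stay within the scatter. Compound 3 is therefore estimated at 45%, between 30% and 62%.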

Compound 3, a percentage reported as inhibition, in the whole organism at one dose (the size of the read-out at that dose, not a potency): 54.5%
For compound 3 the middle estimate is 9.5 percentage points below the measured one, and the stated range covers the measured number.
By their numbers in this assay, from the lowest: compound 2; then compounds 3 and 1 (each within the scatter of the next).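

In this assay, putting 5-sulfanyl-1,3,4-oxadiazol-2-yl on the saturated chain carbon gives a number 12.2 percentage points higher from compound 2 to compound 3 (beyond the scatter), and measured against the unchlorinated thiophene side group it gives a number 0.6 percentage points lower from compound 1 to compound 3 (within the scatter). The longer thiophene-bearing group is thus not required for this level of inhibition, since a single five-membered aromatic ring with 3 hetero atoms can take its place. No data here explain these steps.

As far as these compounds go, whether the sulfanyl group itself matters remains open. An amine or a methyl group in its place on the same ring would test this.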